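Same Atoms, Rejoined: Compound 4 Against Compound 1

The compounds below may be only part of what the source reports. "The series", "measured", "known", "first", "only" and "open" are said of these compounds alone.

In a functional assay on aorta (Rattus norvegicus) (a higher number here means a weaker inhibitor, a lower number a stronger inhibitor), compound 1 `CC(C)(C)[Si](OCCCc1ccc(=O)[nH]n1)(c1ccccc1)c1ccccc1` gives 78300 nM, the highest of the two numbers recorded here; its nearest neighbour is compound 3 `O=c1ccc(COCc2ccccc2)nn1Cc1ccccc1`, which in this assay gives 35300 nM, a gap beyond the usual scatter. Compound 2 `Cn1nc(CCCO)ccc1=O` reaches only the limit of this assay, > 100000 nM, so no number is known for it (the limit of > 100000 nM in this assay, at which 1 of the 3 values shown sits).

Compound 4 `Cn1nc(CCO[Si](c2ccccc2)(c2ccccc2)C(C)(C)C)ccc1=O` keeps every atom of compound 1 but joins them differently: a group of 8 heavy atoms (5 carbon, 2 nitrogen, 1 oxygen; one six-membered aromatic ring with 2 hetero atoms) in place of a group of 8 heavy atoms (5 carbon, 2 nitrogen, 1 oxygen; one six-membered aromatic ring with 2 hetero atoms), on a saturated chain carbon, two bonds along the chain from an oxygen. Going by the values given here, no measured pair shows this change by itself. Compound 2, which carries the same entering group, stands at a limit rather than a number. On that basis compound 4 is expected to be a somewhat weaker inhibitor than compound 1, the step of a 1.5-fold higher number from compound 1 to compound 4 (0.19 log units; within the scatter) being modest but beyond the scatter. For compound 4 the estimated value in this assay is 120000 nM, expected to fall between 45000 nM and 300000 nM, with a real chance that only a limit is reported.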

Compound 4, half-maximal inhibitory concentration: 47000 nM
The estimate for compound 4 lay 2.6-fold (0.41 log units) above the measured number, within the range that was stated.
By their numbers in this assay, from the lowest: compounds 3, 4 and 1 (each within the scatter of the next, the first and the last beyond it). At a limit, above all of these: compound 2.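

In this assay, joining the same atoms differently gives a 1.7-fold lower number from compound 1 to compound 4 (0.22 log units; within the scatter), so this change, on a saturated chain carbon, two bonds along the chain from an oxygen, does not separate compound 4 from compound 1, even though the hydrogen-bond donor counted in the group that leaves is absent from the group that enters. Compound 4 also gives the entering group its first actual number. Compound 2, which carries the same entering group, remains a limit and not a number: the limit of > 100000 nM in this assay, at which 1 of the 4 values shown sits.

The compounds shown cannot tell whether the entering group would read the same with a different group at the far end of the chain. As far as these compounds go, how an amine or a carboxylic acid in place of the silicon-bearing group would read in this assay stays open.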